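Lengthening the Selenium-Bearing Chain from an Amino End

The source may hold more compounds than are shown below. What is called first, only, known or untested is meant among the compounds shown, and "the series" means these compounds.

In a functional assay on A549 cells (Homo sapiens) for inhibition, read by MTT assay, with a stated time of 48 h (on this read-out higher numbers stand for weaker inhibition and lower numbers for stronger inhibition), compound 3 (`COc1ccc(N(C)c2nc(C)nc3ccccc23)cc1OCCN`) gives 122 nM, the middle of three values. Compound 2 (`COc1ccc(N(C)c2nc(C)nc3ccccc23)cc1[Se]C`) lies lower at 11 nM, and compound 1 (`COc1ccc(N(C)c2nc(C)nc3ccccc23)cc1OCCC[Se]C#N`) lies higher at 382 nM. Compound 4 (`COc1ccc(N(C)c2nc(C)nc3ccccc23)cc1OCCCCC[Se]C#N`) has not yet been measured. Its structure departs from that of compound 3 by a group of 6 heavy atoms (4 carbon, 1 nitrogen, 1 selenium; no ring) in place of one nitrogen atom, on a saturated chain carbon, two bonds along the chain from an oxygen on an aromatic ring.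

The closest measured step is a 3.1-fold lower number from compound 1 to compound 3 (0.50 log units; beyond the scatter), which is modest. Compound 1 carries the same selenium and nitrile ending as compound 4, but on a shorter chain, so the change to compound 4 resembles that step in reverse. Going by the values given here, no measured pair shows what lengthening the chain does on its own. The large steps, a 35-fold lower number from compound 1 to compound 2 (1.54 log units; beyond the scatter) and an 11-fold higher number from compound 2 to compound 3 (1.04 log units; beyond the scatter), replace the whole group on the aromatic carbon and bear on this change less directly. A modest rise in this assay is therefore expected, a 2.6-fold higher number from compound 3 to compound 4 (0.42 log units; beyond the scatter). For compound 4, the estimated value is 320 nM, within an expected range of 110 nM to 900 nM.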

Compound 4, half-maximal inhibitory concentration: 2440 nM
Compound 4: middle estimate off by 7.6-fold (0.88 log units), on the low side; the whole stated range lies below it.
By their numbers in this assay, from the lowest: compound 2; then compound 3; then compound 1; then compound 4.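

At this chain position, the longer selenium-bearing chain costs far more than the shorter one did: in this assay the change from the amino end gives a large rise (a 20-fold higher number from compound 3 to compound 4 (1.30 log units; beyond the scatter)). Going by these compounds alone, the two chains ending in selenium and nitrile differ only in length, and they give the first reading of what lengthening does on its own (a 6.4-fold higher number from compound 1 to compound 4 (0.81 log units; beyond the scatter)). The distance from the lowest number in the set grows further (a 220-fold higher number from compound 2 to compound 4 (2.35 log units; beyond the scatter)), and nothing available accounts for any of these rises.

Going by these compounds, whether the numbers keep climbing with a still longer chain remains open. It is also unclear how much depends on the chain and how much on its ending, a question that an amine or a carboxylic acid at the end of the same long chain could help separate.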